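Hydroxyl addition on the methoxyphenyl ring: two cores compared

The compounds below may be only part of what the source reports. "The series", "measured", "known", "first", "only" and "open" are said of these compounds alone.

Compound 1 `COc1ccc(-c2ssc(=S)c2-c2cc(OC)c(OC)c(OC)c2)cc1` and compound 2 `COc1ccc(-c2ssc(=S)c2-c2cc(OC)c(OC)c(OC)c2)cc1O` share one core and differ only by hydroxy in place of hydrogen on an aromatic carbon. In a functional assay on HT-1080 cells (Homo sapiens) for antiproliferative activity, read by MTT assay, with a stated time of 72 h (on this read-out higher numbers stand for weaker inhibition and lower numbers for stronger inhibition), compound 1 gives 18600 nM, while compound 2 gives 231 nM. The resulting step, an 81-fold lower number from compound 1 to compound 2 (1.91 log units; beyond the scatter), is the largest movement among the measured compounds.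

Compound 3 `COc1ccc(-c2ss/c(=N/O)c2-c2cc(OC)c(OC)c(OC)c2)cc1` carries a second core; the difference between the two cores is not broken down here. In this assay compound 3 gives 6660 nM, which places it between compound 1 and compound 2, with both gaps beyond the scatter.

Compound 4 `COc1ccc(-c2ss/c(=N/O)c2-c2cc(OC)c(OC)c(OC)c2)cc1O` has not yet been measured. It is related to compound 3 by hydroxy in place of hydrogen on an aromatic carbon. The place of the change is described in exactly the same words as for the pair of compound 1 and compound 2, so this is the same change applied on the second core. It occurs twice among the compounds shown, once measured and once pending.

For compound 4 a step of about a 56-fold lower number from compound 3 to compound 4 (1.74 log units; beyond the scatter) is expected in this assay. Among the compounds with values here, that expectation rests on the step of an 81-fold lower number from compound 1 to compound 2 (1.91 log units; beyond the scatter), the only measured instance of the change, and carries a wide range since a single instance on a different core gives no check on transfer. Compound 4 is therefore estimated at 120 nM, with a range from 30 nM to 600 nM.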

Compound 4, half-maximal inhibitory concentration: 730 nM
Estimate against measurement, compound 4: 6.1-fold (0.78 log units) below; the measured number lies above the stated range.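

The hydroxy change lowers the number on the second core as well as the first: this assay gives a 9.1-fold lower number from compound 3 to compound 4 (0.96 log units; beyond the scatter), so the direction of the step carries over from the core of compound 1 to the core of compound 3. The size of the step does not carry over, and the two instances differ by more than repeated measurement would explain: the same change on two cores in this assay, an 81-fold lower number (1.91 log units; beyond the scatter) from compound 1 to compound 2 and a 9.1-fold lower number (0.96 log units; beyond the scatter) from compound 3 to compound 4, 8.8-fold (0.95 log units) apart, beyond the scatter of two such steps

Within the data shown here, with only one pair on each core, these notes show that the core affects how much the change achieves, but not which feature of the core is responsible, nor how the step would behave on any further core.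

As far as these compounds go, it remains open whether the lower number depends on hydroxy itself, or whether an amine or a fluorine on the same aromatic carbon would give a similar step on either core. Also open, from the compounds shown here alone, is whether the 3-hydroxy-4-methoxyphenyl result depends on the methoxy group kept in that ring, which could be tested by replacing it with an ethoxy group or a longer chain.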